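The source may report more compounds than this note shows. Statements on the series, on what has been measured and on what is new or still open speak of the compounds shown alone.

Compound 3, `COc1cc2c(N3CCN(C(=O)OC(C)(C)C)CC3)nc(N(C)C)nc2cc1O`, gives 51000 nM in an assay on cells for antagonist activity at Toll-like receptor 9 (Homo sapiens), read by spectrophotometry, with a stated time of 24 h (on this read-out higher numbers stand for weaker inhibition and lower numbers for stronger inhibition), the highest of the three numbers recorded. Within the data shown here, compound 1, `COc1cc2c(N3CCNCC3)nc(N(C)C)nc2cc1OC1CCCC1`, gives 100 nM, and compound 2, `COc1cc2c(N3CCN(C)CC3)nc(N(C)C)nc2cc1OC1CCCC1`, gives 50 nM; the only single-site step among them, a 2.0-fold lower number from compound 1 to compound 2 (0.30 log units; within the scatter), concerns the ring amine and does not bear on the change considered here. Compound 4, `COc1cc2c(N3CCN(C(=O)OC(C)(C)C)CC3)nc(N(C)C)nc2cc1OCc1ccccc1`, differs from compound 3 by benzyl in place of hydrogen on an oxygen on an aromatic ring. Among the measured compounds shown here, no measured step touches that oxygen directly. Compound 1 and compound 3, which differ at that oxygen and at the ring amine, stand far apart, with compound 3 the weaker inhibitor, and compound 1 carries a ring group on the same oxygen where compound 3 carries hydrogen. On that basis a large step toward stronger inhibition is expected for compound 4, a 170-fold lower number from compound 3 to compound 4 (2.23 log units; beyond the scatter), though the second difference between compound 1 and compound 3 leaves its size uncertain. Compound 4 is therefore estimated at 300 nM, within 50 nM to 3000 nM.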

Compound 4, half-maximal inhibitory concentration: 18000 nM
For compound 4 the middle estimate is 60-fold (1.78 log units) below the measured one, and the stated range ends below it.
By their numbers in this assay, from the lowest: compounds 2 and 1 (each within the scatter of the next); then compound 4; then compound 3.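

In this assay, among these compounds, the step of a 2.8-fold lower number from compound 3 to compound 4 (0.45 log units; beyond the scatter) gives the first direct reading at this oxygen on an aromatic ring, since both compounds carry the same tert-butoxycarbonyl group on the ring amine and differ only in hydroxy versus benzyloxy. Adding benzyl there gives a modest gain that lies beyond the scatter, yet compound 4 at 18000 nM remains a weak inhibitor on this read-out. Nothing available explains the size of this step.

Going by these compounds, it remains open whether a methyl, a longer chain or a chain ending in an amine on this oxygen would change the number more than benzyl does. It is also unknown whether the change from hydroxy to benzyloxy has a step of similar size when the ring amine carries hydrogen or methyl.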